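The source may report more compounds than this note shows. Statements on the series, on what has been measured and on what is new or still open speak of the compounds shown alone.

In a functional assay on HepG2 cells (Homo sapiens) for cytotoxicity, read by MTT assay, with a stated time of 72 h (on this read-out higher numbers stand for weaker inhibition and lower numbers for stronger inhibition), compound 1 `Cc1ccc(-n2nc(C(=O)Nc3ccc(Oc4ncnc5ccsc45)cc3)c(C)cc2=O)cc1` gives 25000 nM. For the measured compounds named here, compound 2 `Cc1cc(=O)n(-c2ccc(F)cc2)nc1C(=O)Nc1ccc(Oc2ncnc3ccsc23)cc1` gives 2110 nM in this assay, the lowest of the two numbers so far, reached through a 12-fold lower number from compound 1 to compound 2 (1.07 log units; beyond the scatter). Compound 3 `Cc1cc(=O)n(-c2ccc(F)c(F)c2)nc1C(=O)Nc1ccc(Oc2ncnc3ccsc23)cc1` differs from compound 2 by fluoro in place of hydrogen on an aromatic carbon, ortho to a fluoro group and meta to a large group. Going by the values given here, no measured step adds a second fluoro to this ring; the only step on it, a 12-fold lower number from compound 1 to compound 2 (1.07 log units; beyond the scatter), exchanged a methyl for a fluoro, a different change, so it bears only loosely. A step no larger than the scatter, leaning slightly downward, is therefore expected: a 1.4-fold lower number from compound 2 to compound 3 (0.15 log units; within the scatter). Compound 3 is estimated at 1500 nM, between 500 nM and 5000 nM.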

Compound 3, half-maximal inhibitory concentration: 9230 nM
Compound 3: middle estimate off by 6.2-fold (0.79 log units), on the low side, outside the stated range (above it).
By their numbers in this assay, from the lowest: compound 2; then compound 3; then compound 1.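

In this assay, going from 4-fluorophenyl to 3,4-difluorophenyl gives a 4.4-fold higher number from compound 2 to compound 3 (0.64 log units; beyond the scatter), so on this ring a second fluoro reverses part of the gain seen with the single fluoro rather than adding to it. Compound 3 still keeps some advantage over the 4-methylphenyl compound, with a 2.7-fold lower number from compound 1 to compound 3 (0.43 log units; beyond the scatter) on that comparison. Nothing available here explains the rise. Still open, going by these compounds, is how a chloro, a methoxy or an amino group on that same aromatic carbon would compare with fluoro, and whether a hydrogen-to-fluoro change there always raises the number.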